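Replacing an indole with a tert-butylphenyl on the shared core

A few compounds are considered here, and "the series" means these few. Any claim that something is new, unique, unknown or untested is made for them only; others in the source may bear on it.

Compound 1 `COc1cc(-c2ccnc3cc(-c4ccc5c(ccn5C)c4)nn23)cc(OC)c1OC` and compound 2 `COc1cc(-c2ccnc3cc(-c4cccc5c4ccn5CO)nn23)cc(OC)c1OC` share a core and were tested in a functional assay on HeLa cells (Homo sapiens) for inhibition, read by CCK-8 assay, with a stated time of 48 h; on this read-out lower numbers stand for stronger inhibition and higher numbers for weaker inhibition. In this assay compound 1 gives 19 nM, the lowest of the two numbers shown. Compound 2 gives 456 nM in this assay, a higher number that lies beyond the usual scatter, so compound 1 stands clearly as the stronger of the pair. Compound 3 `COc1cc(-c2ccnc3cc(-c4ccc(C(C)(C)C)cc4)nn23)cc(OC)c1OC` has not yet been measured. It differs from compound 1 in one place: 4-(tert-butyl)phenyl in place of 1-methyl-1H-indol-5-yl on an aromatic carbon. Within the data shown here, no step between two measured compounds is available to calibrate this change. Since the indole of compound 1 is exchanged for a group with no hydrogen-bond acceptor, a moderate loss of inhibition is expected, with the step from compound 1 to compound 3 estimated at a 4.7-fold higher number from compound 1 to compound 3 (0.68 log units; beyond the scatter). Compound 3 is therefore expected to give about 90 nM in this assay, within a range from 25 nM to 400 nM.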

Compound 3, half-maximal inhibitory concentration: > 10000 nM
Compound 3 was reported as a limit; the forecaster's own chance of this, stated with the estimate: 5%; middle value at least 110-fold (2.04 log units) away from the limit.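

Both earlier compounds carry an indole on this aromatic carbon of the shared core, so they could not show whether inhibition survives without one. Compound 3 shows that it does not simply carry over: in this assay, 4-(tert-butyl)phenyl in place of 1-methyl-1H-indol-5-yl gives an at least 520-fold higher number from compound 1 to compound 3 (2.72 log units; beyond the scatter), although both groups have 10 heavy atoms, so matching that count does not preserve inhibition at this position. The figure for compound 3 is a limit, not a number, so this step gives only a minimum: the limit of > 10000 nM in this assay, at which 1 of the 3 values shown sits.

The compounds shown leave open whether the loss goes with removing the fused five-membered ring and its nitrogen or with adding the tert-butyl group. An unsubstituted phenyl, or a phenyl carrying a methoxy group or an amine, would begin to separate these two changes.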